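Swapping propyl for phenyl on a dithioester sulfur chain

The source may hold more compounds than are shown below. What is called first, only, known or untested is meant among the compounds shown, and "the series" means these compounds.

Compound 1, `CC1(C)CC(=O)C(C(=S)SCc2ccccc2)=C(Nc2ccc(Cl)cc2)C1`, gives > 50 ug/mL in a functional assay on PBMC cells (Homo sapiens) for inhibition, read by thymidine incorporation, with a stated time of 72 h (a lower number here means a stronger inhibitor, a higher number a weaker inhibitor), a limit of the assay rather than a number.
Compound 2, `CC1(C)CC(=O)C=C(Nc2ccc(Br)cc2)C1`, gives > 50 ug/mL in this assay, again a limit.
Compound 3, `CCCCSC(=S)C1=C(Nc2ccc(Br)cc2)CC(C)(C)CC1=O`, gives > 50 ug/mL in this assay, also a limit.

Compound 3 therefore stands where every measured compound stands: at the limit of this assay, with no number to rank it against the others, since (the limit of > 50 ug/mL in this assay, at which 3 of the 3 values shown sit). Within the data shown here, the only single-site step, a step that the two limits leave unreadable from compound 2 to compound 3, cannot be read because both ends are limits.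

Compound 4, `CC1(C)CC(=O)C(C(=S)SCc2ccccc2)=C(Nc2ccc(Br)cc2)C1`, differs from compound 3 in one place: phenyl in place of propyl on a saturated chain carbon bound to a sulfur. Among the measured compounds shown here, compound 1 carries this same benzylsulfanyl group and sits at the same limit, so no measured step points to a gain in potency from this change. The expected step that the limit leaves unreadable from compound 3 to compound 4 is none beyond the scatter, with the result most likely reported once more as a limit. Compound 4 is estimated at 60 ug/mL, within 20 ug/mL to 200 ug/mL.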

Compound 4, half-maximal inhibitory concentration: > 50 ug/mL
Compound 4 gave a limit, no number; the forecaster's own chance of this, stated with the estimate: 80%; the middle value lies beyond the limit too.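

Compound 4 gives a limit, as do compound 1 and compound 3, so neither the change from butylsulfanyl to benzylsulfanyl nor bromo in place of chloro can be read as a step: the limit of > 50 ug/mL in this assay, at which 4 of the 4 values shown sit.

The compounds shown leave open which change to the shared core, if any, would give a measurable value in this assay for this series.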